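Fluoro for methyl on the aryl ketone of compound 1

The compounds below may be only part of what the source reports. "The series", "measured", "known", "first", "only" and "open" are said of these compounds alone.

Of the compounds shown here, two have numbers so far. Compound 1, `Cc1ccc(C(=O)CC(=O)OC(C)Cn2cnc3c2c(=O)n(C)c(=O)n3C)cc1`, gives 86.6% in a functional assay on MCF7 cells (Homo sapiens) for antiproliferative activity, read by MTT assay, with a stated time of 72 h, tested at 100 uM; on this read-out lower numbers stand for a stronger effect and higher numbers for a weaker effect at the one concentration tested. Compound 2, `CC(Cn1cnc2c1c(=O)n(C)c(=O)n2C)OCc1cn(-c2cccc3ccccc23)nn1`, gives 93.3% in this assay. The gap between the two sits within the scatter of repeated measurements, so neither compound can be set apart from the other, and both show only a weak effect at the one concentration tested. Among the measured compounds shown here, no step between measured compounds that differ in one place exists in this set.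

The step under consideration goes from compound 1 to compound 3, `CC(Cn1cnc2c1c(=O)n(C)c(=O)n2C)OC(=O)CC(=O)c1ccc(F)cc1`. The change is fluoro in place of methyl on an aromatic carbon. Both groups are single heavy atoms without ring, donor, acceptor or charge, and the exchange reads 4-methylphenyl to 4-fluorophenyl on the carbonyl of compound 1.

For the measured compounds named here, with no comparable step in the data, the expectation rests on the size of the groups exchanged: a step of no consequence beyond the scatter in this assay, in either direction. Compound 3 is therefore estimated at 86%, with a range from 72% to 100%; the expected step is a number 0.6 percentage points lower from compound 1 to compound 3 (within the scatter).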

Compound 3, a percentage reported as activity, at one concentration (the size of the read-out at that concentration, not a potency): 83.8%
Estimate against measurement, compound 3: 2.2 percentage points above; the measured number falls inside the stated range.
By their numbers in this assay, from the lowest: compounds 3, 1 and 2 (each within the scatter of the next).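

In this assay, the series now has its first step between compounds that differ in one place: a number 2.8 percentage points lower from compound 1 to compound 3 (within the scatter), with fluoro in place of methyl on an aromatic carbon, para to a large group. This position therefore accepts the exchange of 4-methylphenyl for 4-fluorophenyl with no change that can be told from the scatter, and compound 3, at 83.8%, still shows only a weak effect at the one concentration tested. Nothing available explains this outcome or ties it to either group.

Open, on these data alone, is whether any group at this place can move the number beyond the scatter, since methyl and fluoro are single heavy atoms without donor, acceptor or charge, whereas an amine, a carboxylic acid or a longer chain would test a different kind of substituent. Also open, as far as these compounds go, is what the shared core and the chain that carries the aryl ketone contribute, as compound 2 differs from compound 1 and compound 3 in more than one place and gives no single-change comparison.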